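A few compounds are considered here, and "the series" means these few. Any claim that something is new, unique, unknown or untested is made for them only; others in the source may bear on it.

In a functional assay on HepG2 cells (Homo sapiens) for cytotoxicity, read by MTT assay, with a stated time of 48 h (on this read-out lower numbers stand for stronger inhibition and higher numbers for weaker inhibition), three compounds have been measured:
compound 1 `Cc1ncc([N+](=O)[O-])n1CCSc1nnc(-c2ccc([N+](=O)[O-])cc2)o1` gives 4100 nM;
compound 2 `Cc1ncc([N+](=O)[O-])n1CCSc1nnc(-c2ccccc2F)o1` gives 3700 nM;
compound 3 `COc1cc(OC)cc(-c2nnc(SCCn3c([N+](=O)[O-])cnc3C)o2)c1` gives 10500 nM.

Compound 2 has the lowest of these three numbers. Its value and that of compound 1 lie within the usual scatter of this assay, so the two cannot be told apart; compound 3 lies beyond the scatter, with a clearly higher number. The next compound, compound 4 `Cc1ncc([N+](=O)[O-])n1CCSc1nnc(-c2ccc(N)nc2)o1`, alters one part of compound 2: 6-aminopyridin-3-yl in place of 2-fluorophenyl on an aromatic carbon. Among the compounds with values here, no two measured compounds differ in only one place, so no measured step can guide the expectation. A modest shift toward a higher number is expected, though it may fall within the scatter. The expected step is a 1.8-fold higher number from compound 2 to compound 4 (0.24 log units; within the scatter). Compound 4 is estimated to give about 6500 nM, likely between 2500 nM and 16000 nM.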

Compound 4, half-maximal inhibitory concentration: 9400 nM
Compound 4: middle estimate off by 1.4-fold (0.16 log units), on the low side; low and high end bracket the measured number.
By their numbers in this assay, from the lowest: compounds 2 and 1 (each within the scatter of the next); then compounds 4 and 3 (each within the scatter of the next).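

In this assay, within the data shown here, putting 6-aminopyridin-3-yl in place of 2-fluorophenyl gives a 2.5-fold higher number from compound 2 to compound 4 (0.40 log units; beyond the scatter), the first single-place change at this position and one that lies beyond the scatter. Both groups have 7 heavy atoms, so the change in the number lies with a swap of ring makeup and substituent, not with the heavy-atom count. No supporting measurement explains the shift. As far as these compounds go, it remains open whether the ring nitrogen, the amino group or the loss of fluorine matters most. A plain phenyl or an unsubstituted pyridine ring at this position would help separate these parts.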